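The source may report more compounds than this note shows. Statements on the series, on what has been measured and on what is new or still open speak of the compounds shown alone.

Compound 3 `C=C(Br)C(=O)Nc1cccc(-c2cn3nc(-c4ccccc4)sc3n2)c1` has the lowest number among the three measured compounds in a functional assay on L1210 cells (Mus musculus) for inhibition, read by cell counting, with a stated time of 2 days (on this read-out lower numbers stand for stronger inhibition and higher numbers for weaker inhibition), with compound 3 giving 600 nM. Compound 2 `C=C(Br)C(=O)Nc1cccc(-c2cn3nc(Cc4cccc(OC)c4)sc3n2)c1` gives 2000 nM, and compound 1 `CCOc1ccc(-c2nn3cc(-c4cccc(N)c4)nc3s2)cc1` gives 155000 nM. Within the data shown here, the only measured step that differs in a single place, a 3.3-fold lower number from compound 2 to compound 3 (0.52 log units; beyond the scatter), concerns the group on the same aromatic carbon that is varied next. Compound 4 `C=C(Br)C(=O)Nc1cccc(-c2cn3nc(-c4ccc(OCC)cc4)sc3n2)c1` differs from compound 3 by ethoxy in place of hydrogen on an aromatic carbon. Compound 1 also carries a 4-ethoxyphenyl group, but it differs from compound 3 in more than one place, so only the two values can be set side by side. Among the measured compounds shown here, no measured step tests an ethoxy added to this phenyl directly, so the change to compound 4 is expected to be small, a 1.2-fold lower number from compound 3 to compound 4 (0.08 log units; within the scatter). The estimate for compound 4 is 500 nM, within 150 nM to 1600 nM.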

Compound 4, half-maximal inhibitory concentration: 790 nM
The estimate for compound 4 lay 1.6-fold (0.20 log units) below the measured number; the range from low to high includes it.
By their numbers in this assay, from the lowest: compounds 3 and 4 (each within the scatter of the next); then compound 2; then compound 1.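

In this assay, among these compounds, adding ethoxy on the phenyl, para to a large group, gives a 1.3-fold higher number from compound 3 to compound 4 (0.12 log units; within the scatter) and so shows that this place accepts the group with no change beyond the scatter. 4-Ethoxyphenyl in place of 3-methoxybenzyl gives a 2.5-fold lower number from compound 2 to compound 4 (0.40 log units; beyond the scatter) and (1-bromoethenyl)carbonyl in place of hydrogen on the nitrogen gives a 200-fold lower number from compound 1 to compound 4 (2.29 log units; beyond the scatter) as the first reading of that group in a single-place change. Nothing available accounts for these steps.

As far as these compounds go, whether an amine, a carboxylic acid or a longer chain at this place on the phenyl would shift the number beyond the scatter remains open.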